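Removing an Ethoxy Group: What the Cell Assay May Show

A few compounds are considered here, and "the series" means these few. Any claim that something is new, unique, unknown or untested is made for them only; others in the source may bear on it.

Of the compounds shown here, three have been measured so far in a functional assay on DLD-1 cells (Homo sapiens) for cytotoxicity, read by MTT assay; a lower number here means a stronger inhibitor, a higher number a weaker inhibitor. Compound 1, with the structure `CCOc1cc(C=C(C(=O)/C=C/c2ccc(O)c(OC)c2)C(=O)/C=C/c2ccc(O)c(OC)c2)ccc1O`, gives 4260 nM in this assay. Compound 2, with the structure `COc1cc(/C=C/C(=O)C(=Cc2ccc(O)cc2)C(=O)/C=C/c2ccc(O)c(OC)c2)ccc1O`, differs from compound 1 in a single place: hydrogen in place of ethoxy on an aromatic carbon. In this assay compound 2 gives 4080 nM, so the change made a 1.0-fold lower number from compound 1 to compound 2 (0.02 log units; within the scatter). The two numbers lie within the usual spread of repeated measurements and show no real separation.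

Compound 3, with the structure `CCOc1cc(C=C(C(=O)/C=C/c2ccc(O)c(OCC)c2)C(=O)/C=C/c2ccc(O)c(OCC)c2)ccc1O`, has a different core; how its core differs from that of compound 1 is not broken down here. In this assay compound 3 gives 1360 nM, the lowest of the three numbers and separated from both compound 1 and compound 2 by more than the usual spread.

Compound 4, with the structure `CCOc1cc(/C=C/C(=O)C(=Cc2ccc(O)cc2)C(=O)/C=C/c2ccc(O)c(OCC)c2)ccc1O`, has not yet been measured. It differs from compound 3 in one place: hydrogen in place of ethoxy on an aromatic carbon. For the measured compounds named here, this is the same change, at the same kind of place, as the one from compound 1 to compound 2, which left the number essentially unchanged. On that basis compound 4 is expected to give about 1400 nM in this assay, with a likely range from 600 nM to 3200 nM. The expected step is a 1.0-fold higher number from compound 3 to compound 4 (0.01 log units; within the scatter), because the earlier pair showed a 1.0-fold lower number from compound 1 to compound 2 (0.02 log units; within the scatter).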

Compound 4, half-maximal inhibitory concentration: 20300 nM
Compound 4: the middle estimate sits 15-fold (1.16 log units) below what was measured; measured number above the stated range.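

In this assay, putting hydrogen in place of ethoxy on the aromatic carbon ortho to a hydroxy group now gives a 15-fold higher number from compound 3 to compound 4 (1.17 log units; beyond the scatter), a large weakening, whereas the same change on the other core gave no real separation. The effect of this change therefore cannot simply be carried from one core to the other in this series, and the two steps truly differ: the same change on two cores in this assay, a 1.0-fold lower number (0.02 log units; within the scatter) from compound 1 to compound 2 and a 15-fold higher number (1.17 log units; beyond the scatter) from compound 3 to compound 4, 16-fold (1.19 log units) apart, beyond the scatter of two such steps This does not show why they differ, because the numbers say only that the outcome depends on the core, not which feature of the core is responsible, and two pairs give no rule for predicting the change on any further core.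

The compounds shown leave open whether the ethoxy group on the core of compound 3 is specifically needed or whether other groups at that carbon could serve as well, as only ethoxy and hydrogen are compared there. A longer chain such as propoxy, or an amine or a carboxylic acid at the same carbon, would help show how much the number depends on what sits at that place.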